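4-Fluorobenzyl to 3-fluorobenzyl in the series

This account rests on a few compounds, and the source may have more. Where it says the series, first, only, none or still open, it means among the compounds named here.

In a functional assay on HL-60 cells (Homo sapiens) for inhibition, read by CCK-8 assay, with a stated time of 48 h, tested at 20 uM (a higher number here means more inhibition of growth at the concentration tested, a lower number less inhibition of growth), compound 1 `N#C/C(=C\c1ccccc1OS(=O)(=O)c1ccc([N+](=O)[O-])cc1)C(=O)Nc1nnc(Cc2cccc3ccccc23)s1` gives 18%. Going by the values given here, compound 2 `N#C/C(=C\c1ccccc1OS(=O)(=O)c1ccc([N+](=O)[O-])cc1)C(=O)Nc1nnc(Cc2ccc(F)cc2)s1` gives 18% and so stands level with compound 1, its only measured neighbour. Compound 3 `N#C/C(=C\c1ccccc1OS(=O)(=O)c1ccc([N+](=O)[O-])cc1)C(=O)Nc1nnc(Cc2cccc(F)c2)s1` keeps the core of compound 2 and carries 3-fluorophenyl in place of 4-fluorophenyl on a saturated chain carbon bound to an aromatic carbon. Among the compounds with values here, one measured step bears on this change. Replacing naphthalen-1-yl with 4-fluorophenyl at the same place gave no change at the digits printed from compound 1 to compound 2 (within the scatter). Within the data shown here, no measured pair yet compares 3-fluorophenyl with 4-fluorophenyl, so that step is only indirect evidence. Among the measured compounds shown here, with nothing beyond the scatter at this place so far, no shift in either direction is expected. The expected step is no change at the digits printed from compound 2 to compound 3 (within the scatter). Compound 3 is estimated at 18%, with an expected range of 7% to 30%.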

Compound 3, percent growth inhibition at one concentration: 18%
Beside the measured number, compound 3's estimate shows no gap at the digits printed; the range from low to high includes it.
By their numbers in this assay, from the lowest: compounds 1, 2 and 3 (each within the scatter of the next).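

Moving the fluorine gives the first direct comparison of two fluorophenyl groups at this place: in this assay, the change from 4-fluorobenzyl to 3-fluorobenzyl reads no change at the digits printed from compound 2 to compound 3 (within the scatter). The naphthalen-1-yl comparison now extends to the second fluorophenyl group and reads no change at the digits printed from compound 1 to compound 3 (within the scatter), so all three groups on the saturated chain carbon lie within the scatter of one another at the single concentration tested. No available measurement gives a reason for this flat reading.

The compounds shown leave open whether a group of a different kind at this place, such as a primary amine or a carboxylic acid on a longer chain, would move the reading beyond the scatter. Also open, on these data alone, is whether these three compounds would separate at a different concentration.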